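Second Methoxy on the Aryl Group of Compound 2

The source may hold more compounds than are shown below. What is called first, only, known or untested is meant among the compounds shown, and "the series" means these compounds.

Measured so far:
compound 1 `CCC1=C(O)c2c(oc(-c3cccc(F)c3)cc2=O)C(CC)(CC)C1=O`: > 56.2 uM
compound 2 `CCC1=C(O)c2c(oc(-c3ccccc3OC)cc2=O)C(CC)(CC)C1=O`: 40.8 uM
compound 3 `CCC1=C(O)c2c(oc(-c3ccc(OC)c(F)c3)cc2=O)C(CC)(CC)C1=O`: 26.7 uM

In a functional assay on KB cells (Homo sapiens) for antiproliferative activity, read by sulforhodamine B assay, with a stated time of 3 days (a lower number here means that less compound is needed, a higher number that more compound is needed for the effect), compound 1 gives only a limit and not a number, sitting at the limit of > 56.2 uM in this assay, at which 1 of the 3 values shown sits. Compound 2 and compound 3 stand within the scatter of each other, with a 1.5-fold lower number from compound 2 to compound 3 (0.18 log units; within the scatter). The cores of compound 1 and compound 2 differ by 2-methoxyphenyl in place of 3-fluorophenyl on an aromatic carbon, giving an at least 1.3-fold lower number from compound 1 to compound 2 (0.13 log units; that floor lies within the scatter).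

Compound 4 `CCC1=C(O)c2c(oc(-c3cc(OC)ccc3OC)cc2=O)C(CC)(CC)C1=O` is not yet measured. It differs from compound 2 by methoxy in place of hydrogen on an aromatic carbon. The same change is seen from compound 1 to compound 3, (methoxy in place of hydrogen on an aromatic carbon), where it gave an at least 2.1-fold lower number from compound 1 to compound 3 (0.32 log units; beyond the scatter). The surroundings differ, though: in compound 3 the methoxy sits ortho to a fluoro group and para to a large group, in compound 4 meta to a large group and para to a methoxy group, so this is the same kind of change rather than the same one.

The step from compound 2 to compound 4 is expected to be a 1.6-fold lower number from compound 2 to compound 4 (0.21 log units; within the scatter), resting on the earlier step of an at least 2.1-fold lower number from compound 1 to compound 3 (0.32 log units; beyond the scatter), which is only a floor. Compound 4 is therefore estimated at 25 uM, most likely between 10 uM and 60 uM.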

Compound 4, concentration for half-maximal effect: 8.8 uM
Beside the measured number, compound 4's estimate is 2.8-fold (0.45 log units) above it; the whole stated range lies above it.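

In this assay, methoxy in place of hydrogen, meta to a large group and para to a methoxy group, gives a 4.6-fold lower number from compound 2 to compound 4 (0.67 log units; beyond the scatter). The same kind of change lowers the number on both cores, which shows the direction carrying over in these two cases but not that its size does: the same change on two cores in this assay, an at least 2.1-fold lower number (0.32 log units; beyond the scatter) from compound 1 to compound 3 and a 4.6-fold lower number (0.67 log units; beyond the scatter) from compound 2 to compound 4; the limit leaves it open whether they differ. The earlier step is only a floor, as compound 1 gives a limit and not a number: the limit of > 56.2 uM in this assay, at which 1 of the 4 values shown sits.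

The compounds shown leave open whether a hydroxyl, an amine or a longer ethoxy chain in the place of this methoxy would give a step of like size. They also leave open how the change would behave on a third core.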